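Enlarging the Amide Substituent of Compound 1

This account rests on a few compounds, and the source may have more. Where it says the series, first, only, none or still open, it means among the compounds named here.

Compound 1 `COc1c(C)cnc(CN2CC(=O)N(CC(C)C)c3c(Cl)nc(N)nc32)c1C` is the reference point of this set. In a functional assay on HT-29 cells (Homo sapiens) for inhibition (a lower number here means a stronger inhibitor, a higher number a weaker inhibitor), compound 1 gives 40 nM, the lowest number among the three measured compounds. Compound 2 `COc1c(C)cnc(CN2c3nc(N)nc(Cl)c3NC(=O)[C@@H]2C)c1C` gives 660 nM in this assay, and compound 3 `COc1c(C)cnc(CN2CC(=O)N(CCCC(C)C)c3c(Cl)nc(N)nc32)c1C` gives 2260 nM, so compound 1 stands clearly apart from both, each gap being well beyond the usual scatter.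

The new compound 4 `COc1c(C)cnc(CN2CC(=O)N(C(C)C(=O)NCCN(C)C)c3c(Cl)nc(N)nc32)c1C` differs from compound 1 in one place: 1-((2-(dimethylamino)ethyl)carbamoyl)ethyl in place of isobutyl on an amide-type nitrogen in a ring. The group that enters is far larger than the one that leaves, and it sits on the same ring nitrogen where the measured series already shows how sensitive this position is.

Within the data shown here, only one measured step bears directly on this change: a 57-fold higher number from compound 1 to compound 3 (1.75 log units; beyond the scatter). There, merely lengthening the chain on that nitrogen by a few carbons weakened inhibition sharply. Compound 4 carries a chain longer still, so a weaker inhibitor is expected, and a step of comparable size in the same direction seems likely, namely a 38-fold higher number from compound 1 to compound 4 (1.57 log units; beyond the scatter) as the expected outcome. For compound 4 the estimated value in this assay is 1500 nM, with a plausible range from 300 nM to 8000 nM.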

Compound 4, half-maximal inhibitory concentration: 100 nM
The estimate for compound 4 lay 15-fold (1.18 log units) above the measured number, and the stated range ends above it.
By their numbers in this assay, from the lowest: compound 1; then compound 4; then compound 2; then compound 3.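

The ring amide nitrogen does not simply penalize a larger group: replacing isobutyl with 1-((2-(dimethylamino)ethyl)carbamoyl)ethyl, a group of 10 heavy atoms, gives only a 2.5-fold higher number from compound 1 to compound 4 (0.40 log units; beyond the scatter), a modest loss that is nevertheless beyond the scatter. Compared with the all-carbon 4-methylpentyl chain of compound 3, the same group gives a 23-fold lower number from compound 3 to compound 4 (1.35 log units; beyond the scatter), so the earlier loss on lengthening the chain does not extend to every large group at this nitrogen, and compound 4 goes against any simple rule that bigger is worse here. No measurement in this set explains why the chain containing the carbonyl and the dimethylamino group fares so much better than the plain carbon chain.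

The entering group differs from isobutyl in its branching methyl, its carbamoyl unit and its dimethylamino end all at once, and the compounds shown cannot separate what each of these parts contributes. Going by these compounds, it also remains open how a carboxylic acid or a morpholine in place of the dimethylamino end would compare, and whether a shorter chain between the carbamoyl unit and that amine would change the result.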